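A few compounds are considered here, and "the series" means these few. Any claim that something is new, unique, unknown or untested is made for them only; others in the source may bear on it.

Three compounds built on a shared core were tested in a functional assay on MCF7 cells (Homo sapiens) for cytotoxicity, read by MTT assay, with a stated time of 72 h, tested at 10 uM; on this read-out higher numbers stand for more inhibition of growth at the one concentration tested and lower numbers for less inhibition of growth. Compound 1, `Cc1cccc(/C(N)=N/NC(=S)N2CCCCC2)n1`, gives 39% in this assay, the lowest of the three numbers. Compound 3, `N/C(=N\NC(=S)N1CCOCC1)c1ccc(F)cn1`, gives 39.5% in this assay, a value that lies within the usual scatter of the value of compound 1, so the two cannot be told apart. Compound 2, `Cc1ccnc(/C(N)=N/NC(=S)N2CCCCCC2)c1`, gives 60.3% in this assay, which stands beyond the scatter above compound 1. No two of these three compounds differ in just one place, so none of the gaps between them can be tied to a single structural change.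

Compound 4, `Cc1cccc(/C(N)=N/NC(=S)N2CCCC2)n1`, differs from compound 1 in one place: pyrrolidin-1-yl in place of piperidin-1-yl on a thiocarbonyl carbon. The measured compounds offer no direct guide to such an exchange, since compound 2 and compound 3 each differ from compound 1 both on the thiocarbonyl carbon and elsewhere in the molecule. With nothing pointing one way or the other, compound 4 is expected to sit close to compound 1, and the step of a number 1 percentage points lower from compound 1 to compound 4 (within the scatter) is expected to stay within the scatter. The estimate for compound 4 in this assay is 38%, with a range from 24% to 52%.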

Compound 4, percent growth inhibition at one concentration: 38.2%
For compound 4 the middle estimate is 0.2 percentage points below the measured one, within the range that was stated.
By their numbers in this assay, from the lowest: compounds 4, 1 and 3 (each within the scatter of the next); then compound 2.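

In this assay, putting pyrrolidin-1-yl in place of piperidin-1-yl on a thiocarbonyl carbon gives a number 0.8 percentage points lower from compound 1 to compound 4 (within the scatter), and this is the only pair shown so far that differs in one place. On the core of compound 1, then, the five-membered and six-membered rings at this position cannot be told apart by this read-out, so this particular change of ring size leaves no measurable mark on growth inhibition at the one concentration tested. No supporting measurement bears on why the two rings give such similar results, so the finding stands as an observation only.

The compounds shown leave open whether the position stays just as undemanding when the ring gives way to something of a different kind, such as an open-chain diethylamino group or a piperazin-1-yl ring, which would show whether a ring is needed there at all. They also leave open whether swapping these same two rings would give an equally small step on a core carrying other substituents.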